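Methyl on a Pendant Phenyl in Two Dichloro and Dibromo Cores

The compounds below may be only part of what the source reports. "The series", "measured", "known", "first", "only" and "open" are said of these compounds alone.

Measured compounds:
compound 1 `Cc1[nH]c2ccccc2c1C1=C(Cl)C(=O)C(c2c(-c3ccccc3)[nH]c3ccccc23)=C(Cl)C1=O` gives 2.29 ug/mL
compound 2 `Cc1ccc(-c2[nH]c3ccccc3c2C2=C(Cl)C(=O)C(c3c(C)[nH]c4ccccc34)=C(Cl)C2=O)cc1` gives 2.8 ug/mL
compound 3 `Cc1[nH]c2ccccc2c1C1=C(Br)C(=O)C(Br)=C(c2c(-c3ccccc3)[nH]c3ccccc23)C1=O` gives 3.02 ug/mL

Compound 1 and compound 2 were tested in a functional assay on MCF7 cells (Homo sapiens) for antiproliferative activity, read by CCK-8 assay, with a stated time of 48 h; a lower number here means a stronger inhibitor, a higher number a weaker inhibitor. Compound 1 gives 2.29 ug/mL, compound 2 gives 2.8 ug/mL, and the step between them is a 1.2-fold higher number from compound 1 to compound 2 (0.09 log units; within the scatter). The change that produces it is methyl in place of hydrogen on an aromatic carbon.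

Compound 3 `Cc1[nH]c2ccccc2c1C1=C(Br)C(=O)C(Br)=C(c2c(-c3ccccc3)[nH]c3ccccc23)C1=O` carries a different core; how its core differs from that of compound 1 is not broken down here. In this assay compound 3 gives 3.02 ug/mL. Its value and those of compound 1 and compound 2 all lie within the scatter of one another, so no order among the three can be read.

Compound 4 `Cc1ccc(-c2[nH]c3ccccc3c2C2=C(Br)C(=O)C(Br)=C(c3c(C)[nH]c4ccccc34)C2=O)cc1` is not yet measured. It stands to compound 3 as compound 2 stands to compound 1: the change is methyl in place of hydrogen on an aromatic carbon, the same change at the same place. On the basis of the step from compound 1 to compound 2, compound 4 is expected to move by a 1.2-fold higher number from compound 3 to compound 4 (0.06 log units; within the scatter) from compound 3. Compound 4 is thus estimated at 3.5 ug/mL in this assay, within a range from 2 ug/mL to 6.5 ug/mL.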

Compound 4, half-maximal inhibitory concentration: 6.85 ug/mL
Estimate against measurement, compound 4: 2.0-fold (0.29 log units) below; the measured number lies above the stated range.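

In this assay, the change from phenyl to 4-methylphenyl on the core of compound 3 gives a 2.3-fold higher number from compound 3 to compound 4 (0.36 log units; beyond the scatter), a modest step and the only one of the two that can be read as a real shift. This does not show that the methyl group weakens compounds on the core of compound 1, where the step stays within the scatter, and two pairs are too few to support a rule for the series. Nor does it show that the two cores respond differently, since the gap between the steps is no larger than such steps can scatter, so the change may carry across cores, though this remains unproven: the same change on two cores in this assay, a 1.2-fold higher number (0.09 log units; within the scatter) from compound 1 to compound 2 and a 2.3-fold higher number (0.36 log units; beyond the scatter) from compound 3 to compound 4, 1.9-fold (0.27 log units) apart, within the scatter of two such steps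

The compounds shown leave open how a methoxy group, an amine or a carboxylic acid would read in this assay in the place of this methyl group. They also leave open whether a longer chain there would extend the step seen on either core.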